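The source may report more compounds than this note shows. Statements on the series, on what has been measured and on what is new or still open speak of the compounds shown alone.

Compound 3 `O=C1[C@@H](NS(=O)(=O)c2cc3cccnc3s2)CCN1Cc1cc2[nH]cccc-2n1` has the highest number of the three measured compounds in an assay on isolated protein for inhibition of coagulation factor X (Oryctolagus cuniculus), tested at 1 uM; on this read-out lower numbers stand for less inhibition and higher numbers for more inhibition at the one concentration tested (going by the name of the read-out): compound 3 gives 44%. Compound 1 `O=C1[C@@H](NS(=O)(=O)c2cc3cccnc3s2)CCN1CCNc1ccncc1` gives 23% in this assay, and compound 2 `O=C1[C@@H](NS(=O)(=O)c2nc3cc(Cl)ccc3[nH]2)CCN1Cc1cc2[nH]cccc-2n1` gives 14%. The two steps leading to compound 3 are both beyond the scatter: a number 21 percentage points higher from compound 1 to compound 3 (beyond the scatter), where the change sits on the saturated chain carbon bound to the ring amide nitrogen, and a number 30 percentage points higher from compound 2 to compound 3 (beyond the scatter), where the change sits on the sulfonyl sulfur.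

Compound 4 `O=C1[C@@H](NS(=O)(=O)c2ccc(-c3ccon3)s2)CCN1Cc1cc2[nH]cccc-2n1` has not yet been measured. Its difference from compound 3 is a group of 10 heavy atoms (7 carbon, 1 nitrogen, 1 oxygen, 1 sulfur; one five-membered aromatic ring with 1 hetero atom, one five-membered aromatic ring with 2 hetero atoms) in place of a group of 9 heavy atoms (7 carbon, 1 nitrogen, 1 sulfur; one five-membered aromatic ring with 1 hetero atom, one six-membered aromatic ring with 1 hetero atom), on a sulfonyl sulfur.

For the measured compounds named here, only the step from compound 2 to compound 3 bears on this change, since it is the one that alters the group on the sulfonyl sulfur, and there it moved the number by a modest amount. Going by the values given here, that shows the sulfonyl group matters, but the entering group here has no measured precedent, so the direction of any step is open. The step for compound 4 is expected to be a number 9 percentage points lower from compound 3 to compound 4 (within the scatter), with wide uncertainty. Compound 4 is therefore estimated at 35% in this assay, within a range from 10% to 65%.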

Compound 4, a percentage reported as inhibition, at one concentration (the size of the read-out at that concentration, not a potency): 31%
For compound 4 the middle estimate is 4 percentage points above the measured one; measured number inside the range.
By their numbers in this assay, from the lowest: compounds 2, 1 and 4 (each within the scatter of the next, the first and the last beyond it); then compound 3.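

In this assay, the group on the sulfonyl sulfur now has three measured versions on an otherwise identical structure, and they fall into a clear order. Replacing the group of compound 3 with 5-(1,2-oxazol-3-yl)thiophen-2-yl gives a number 13 percentage points lower from compound 3 to compound 4 (beyond the scatter), whereas the same group in place of 5-chloro-1H-benzimidazol-2-yl gives a number 17 percentage points higher from compound 2 to compound 4 (beyond the scatter), so compound 4 at 31% lies beyond the scatter from both. Ring sizes alone do not set this order, since the groups of compound 2 and compound 3 each hold one five-membered and one six-membered aromatic ring yet lie on opposite sides of compound 4, which has two five-membered aromatic rings, and nothing shown gives a measured explanation for these differences.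

Going by these compounds, what a carboxylic acid or an amine in place of the 1,2-oxazol-3-yl part would do to the number stays open. Also open, on these data alone, is whether the same order of sulfonyl groups would hold with the group that compound 1 carries on the ring amide nitrogen.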